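This account rests on a few compounds, and the source may have more. Where it says the series, first, only, none or still open, it means among the compounds named here.

Three amides sharing one core have been tested in an in vitro functional assay on HEK293-A cells for antagonist activity at metabotropic glutamate receptor 5 (Rattus norvegicus), read by calcium flux; on this read-out lower numbers stand for stronger inhibition and higher numbers for weaker inhibition. Compound 1 `N#Cc1cc(F)cc(C(=O)Nc2cccnc2)c1` reports only a limit of the assay, > 30000 nM. Compound 2 `N#Cc1cc(F)cc(C(=O)Nc2nccs2)c1` likewise reports only a limit, > 10000 nM. Compound 3 `COc1cccc(NC(=O)c2cc(F)cc(C#N)c2)n1` gives 1510 nM. Compound 2 therefore stands at the limit of > 10000 nM in this assay, at which 1 of the 3 values shown sits, without a number of its own. Going by the values given here, the only measured step, a step that the two limits leave unreadable from compound 1 to compound 2, is unreadable, as each of its ends is a limit, and it concerns a different change. Compound 4 `Cc1cnc(NC(=O)c2cc(F)cc(C#N)c2)s1` differs from compound 2 by methyl in place of hydrogen on an aromatic carbon. Among the compounds with values here, no measured step bears on this change, so the step of an at least 2.5-fold lower number from compound 2 to compound 4 (0.39 log units; beyond the scatter) is expected only loosely, with a sizeable chance of another limit. Compound 4 is estimated at 4000 nM, ranging from 800 nM to 30000 nM.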

Compound 4, half-maximal inhibitory concentration: 863 nM
Beside the measured number, compound 4's estimate is 4.6-fold (0.67 log units) above it; measured number inside the range.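

In this assay, methyl in place of hydrogen on the aromatic carbon next to the ring sulfur gives an at least 11-fold lower number from compound 2 to compound 4 (1.06 log units; beyond the scatter). This single added carbon turns a thiazole amide that reported only a limit into one with a measured number, and the 5-methyl-1,3-thiazol-2-yl group also gives an at least 34-fold lower number from compound 1 to compound 4 (1.54 log units; beyond the scatter). Both steps start from a limit, so their full sizes stay unknown; for compound 2 the limit is: the limit of > 10000 nM in this assay, at which 1 of the 4 values shown sits.

On these data alone, whether this carbon is specific to methyl stays open. An ethyl group or an amine in the same place could give a quite different number.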